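The compounds below may be only part of what the source reports. "The series", "measured", "known", "first", "only" and "open" are said of these compounds alone.

Measured so far:
compound 1, `Cc1ccc(Nc2cc(NC(=O)Nc3c(Cl)cccc3Cl)ncn2)cc1F`, 45.3%
compound 2, `COc1ccc(F)cc1Nc1cc(NC(=O)Nc2c(Cl)cccc2Cl)ncn1`, 73.1%
compound 3, `COc1cc(NC(=O)Nc2cc(Nc3ccc(C)c(F)c3)ncn2)cc(OC)c1`, 38%

Of the compounds shown here, three have been measured in a functional assay on NCI-H1581 cells (Homo sapiens) for inhibition, read by MTT assay, with a stated time of 48 h, tested at 10 uM; a lower number here means less inhibition, a higher number more inhibition at the concentration tested (going by the name of the read-out). Compound 1 gives 45.3% in this assay, compound 2 gives 73.1%, and compound 3 gives 38%; compound 3 and compound 1 lie within the scatter of each other, so no order between them is claimed. Compound 1 and compound 2 differ in one place, (5-fluoro-2-methoxyphenyl in place of 3-fluoro-4-methylphenyl on a nitrogen on an aromatic ring), and this change made a step of a number 27.8 percentage points higher from compound 1 to compound 2 (beyond the scatter). How the core of compound 3 differs from the core of compound 1 is not broken down here.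

Compound 4, `COc1cc(NC(=O)Nc2cc(Nc3cc(F)ccc3OC)ncn2)cc(OC)c1`, has not yet been measured. It differs from compound 3 by 5-fluoro-2-methoxyphenyl in place of 3-fluoro-4-methylphenyl on a nitrogen on an aromatic ring, the same change that separates compound 1 from compound 2, at a place described in the same words. Resting only on the step of a number 27.8 percentage points higher from compound 1 to compound 2 (beyond the scatter), a step of similar direction is expected from compound 3 to compound 4, a number 24 percentage points higher from compound 3 to compound 4 (beyond the scatter), though the cores differ and the change has been seen only once. Compound 4 is estimated at 62%, with a range from 42% to 80%.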

Compound 4, a percentage reported as inhibition, at one concentration (the size of the read-out at that concentration, not a potency): 42.1%
Compound 4: the middle estimate sits 19.9 percentage points above what was measured; low and high end bracket the measured number.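

In this assay, the change that separates compound 1 from compound 2 gave a number 4.1 percentage points higher from compound 3 to compound 4 (within the scatter), so the gain seen on the core of compound 1 did not carry over in size to the core of compound 3: the same change on two cores in this assay, a number 27.8 percentage points higher (beyond the scatter) from compound 1 to compound 2 and a number 4.1 percentage points higher (within the scatter) from compound 3 to compound 4, 23.7 percentage points apart, beyond the scatter of two such steps The result therefore shows that, in these two pairs, the size of the step depends on the core, and the group on the amide-type nitrogen matters in its own right, since 3,5-dimethoxyphenyl in place of 2,6-dichlorophenyl gave a number 31 percentage points lower from compound 2 to compound 4 (beyond the scatter). It does not show why the two steps differ, and two pairs give no rule for any other core in the series.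

The compounds shown leave open how the same change would behave with a plain phenyl or a 2,6-dimethylphenyl on the amide-type nitrogen. They also leave open what a morpholine or a carboxylic acid on either aromatic ring would do to the reading.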